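A few compounds are considered here, and "the series" means these few. Any claim that something is new, unique, unknown or untested is made for them only; others in the source may bear on it.

Measured compounds:
Compound 1 `Nc1nc(N)c2c(-c3ccsc3)cn([C@@H]3O[C@H](CO)[C@@H](O)[C@H]3O)c2n1` — > 20000 nM in a functional assay on K562 cells (Homo sapiens), read by MTT assay, with a stated time of 72 h; a lower number here means a stronger inhibitor, a higher number a weaker inhibitor
Compound 2 `C#Cc1cn([C@@H]2O[C@H](CO)[C@@H](O)[C@H]2O)c2nc(C)nc(N)c12` — 3290 nM
Compound 3 `Cc1nc(N)c2c(-c3cc4ccccc4o3)cn([C@@H]3O[C@H](CO)[C@@H](O)[C@H]3O)c2n1` — 4990 nM

The value given for compound 1 is a limit of this assay, not a number (the limit of > 20000 nM in this assay, at which 1 of the 3 values shown sits).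

Compound 3 has the highest of the two numbers in this assay; its nearest neighbour is compound 2, and the step of a 1.5-fold higher number from compound 2 to compound 3 (0.18 log units; within the scatter) is within the scatter. Among the measured compounds shown here, the only measured step, from the ethynyl group to 1-benzofuran-2-yl, therefore changed little.

Compound 4 `Cc1nc(N)c2c(-c3ccsc3)cn([C@@H]3O[C@H](CO)[C@@H](O)[C@H]3O)c2n1` is not yet measured. It differs from compound 3 as follows: thiophen-3-yl in place of 1-benzofuran-2-yl on an aromatic carbon. For the measured compounds named here, no measured step swaps one five-membered aromatic group for another, so the step from compound 2 to compound 3 is the only guide, and it was small. Compound 1 also carries thiophen-3-yl, with a different group elsewhere on the shared core, and gives only a limit.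

On this basis compound 4 is expected to give 8000 nM in this assay, with a range of 2500 nM to 25000 nM, which means an estimated step of a 1.6-fold higher number from compound 3 to compound 4 (0.20 log units; within the scatter); a weaker result than compound 3 is considered the likelier direction, but the step is expected to stay close to the scatter.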

Compound 4, half-maximal inhibitory concentration: > 20000 nM
Compound 4: a limit, no number; the forecaster's own chance of this, stated with the estimate: 30%; at least 2.5-fold (0.39 log units) between middle value and limit.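

In this assay, the aromatic carbon two ring bonds from the ring nitrogen is not indifferent to the group it carries: thiophen-3-yl in place of 1-benzofuran-2-yl gives an at least 4.0-fold higher number from compound 3 to compound 4 (0.60 log units; beyond the scatter), and thiophen-3-yl in place of ethynyl gives an at least 6.0-fold higher number from compound 2 to compound 4 (0.78 log units; beyond the scatter). Compound 2 and compound 3 lie within the scatter of each other, so the earlier step gave no sign of this, and with three groups compared, the order does not follow group size, since the 1-benzofuran-2-yl compound holds up while the thiophen-3-yl compound does not. Compound 4 gives a limit of this assay, as does compound 1: the limit of > 20000 nM in this assay, at which 2 of the 4 values shown sit.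

From the compounds shown here alone, the step between compound 1 and compound 4 cannot be read, so the effect of methyl against amino on the shared core remains open. Also open, going by these compounds, is whether a phenyl ring, a furan-2-yl group or a longer alkynyl chain at this position behaves like ethynyl and 1-benzofuran-2-yl or like thiophen-3-yl.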